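This account rests on a few compounds, and the source may have more. Where it says the series, first, only, none or still open, it means among the compounds named here.

Measured compounds:
Compound 1 `Fc1ccc(Cn2cc(CSC(=S)N3CCNCC3)nn2)cc1` gives > 128000 nM, a limit of the assay.
Compound 2 `COc1ccc(Cn2cc(CSC(=S)N3CCN(C(=O)OCc4ccccc4)CC3)nn2)cc1` gives > 128000 nM, also a limit of the assay.
Compound 3 `Cc1ccc(-n2cc(CSC(=S)N3CCN(C(=O)OC(C)(C)C)CC3)nn2)cc1` gives > 128000 nM, again a limit of the assay.

In a functional assay on PC-3 cells (Homo sapiens) for inhibition, read by MTT assay, with a stated time of 72 h (on this read-out lower numbers stand for stronger inhibition and higher numbers for weaker inhibition), compound 1 stands at a limit and no number is known for it. The same holds for the other two, and all three sit at the limit of > 128000 nM in this assay, at which 3 of the 3 values shown sit, so compound 1 cannot be placed above or below them. Compound 4 `Fc1ccccc1Cn1cc(CSC(=S)N2CCNCC2)nn1` differs from compound 1 by 2-fluorophenyl in place of 4-fluorophenyl on a saturated chain carbon bound to an aromatic nitrogen. Going by the values given here, no step between measured compounds is known here. With nothing but limits to go on, no movement beyond the scatter is expected from compound 1 to compound 4, and the expected step is a step that the limit leaves unreadable from compound 1 to compound 4. Compound 4 is therefore estimated at 200000 nM, in a range from 60000 nM to 600000 nM, most probably reported again only as a limit.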

Compound 4, half-maximal inhibitory concentration: 56200 nM
Beside the measured number, compound 4's estimate is 3.6-fold (0.55 log units) above it; measured number outside the range, below it.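

In this assay, 2-fluorophenyl in place of 4-fluorophenyl gives an at least 2.2-fold lower number from compound 1 to compound 4 (0.35 log units; beyond the scatter), so the placing of the fluorine on this ring can separate a measurable compound from one at the limit. Going by these compounds alone, compound 4 is the first compound here with an actual number, 56200 nM. The full size of the step cannot be read because compound 1 gives only a limit: the limit of > 128000 nM in this assay, at which 3 of the 4 values shown sit.

The compounds shown leave open whether 3-fluorophenyl, 2-chlorophenyl or plain phenyl at this place would give a lower or higher number.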